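The source may report more compounds than this note shows. Statements on the series, on what has been measured and on what is new or still open speak of the compounds shown alone.

Measured compounds:
- compound 1 `c1cnc(-c2ccccc2OCC2=NCCN2)nc1` gives < 100000 nM in a functional assay for activation of Alpha-1B adrenergic receptor (Homo sapiens), read by calcium flux; a lower number here means that less compound is needed, a higher number that more compound is needed for the effect; this is a limit of the assay, not a number.
- compound 2 `c1ccc(-c2cnccn2)c(OCC2=NCCN2)c1` gives 631 nM in this assay.
- compound 3 `c1ccc(-c2nccs2)c(OCC2=NCCN2)c1` gives 20 nM in this assay.

Compound 2 stands highest of the two numbers in hand; its nearest neighbour is compound 3, reached by a 32-fold lower number from compound 2 to compound 3 (1.50 log units; beyond the scatter), a step beyond the scatter. The steps a step that the limit leaves unreadable from compound 1 to compound 2 and a step that the limit leaves unreadable from compound 1 to compound 3 cannot be sized, since compound 1 sits at the limit described by the limit of < 100000 nM in this assay, at which 1 of the 3 values shown sits.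

Compound 4 `Cc1ccoc1-c1ccccc1OCC1=NCCN1` is not yet measured. It differs from compound 2 in one place: 3-methylfuran-2-yl in place of pyrazin-2-yl on an aromatic carbon. For the measured compounds named here, the only readable step that bears on this change is the one from compound 2 to compound 3, where a six-membered diazine gave way to a five-membered aromatic ring and the number fell by a 32-fold lower number from compound 2 to compound 3 (1.50 log units; beyond the scatter). The change to compound 4 again replaces the six-membered ring with a five-membered one, though with a different hetero atom and an added methyl, so a drop of similar direction but less certain size is expected.

Compound 4 is therefore estimated at 60 nM in this assay, with a range of 15 nM to 250 nM. This estimate corresponds to an expected step of an 11-fold lower number from compound 2 to compound 4 (1.02 log units; beyond the scatter).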

Compound 4, half-maximal effective concentration: < 100000 nM
Compound 4 was reported as a limit; the forecaster's own chance of this, stated with the estimate: 3%; the middle value does not contradict the limit.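

For the compounds shown here, compound 4 is reported only as a limit, as is compound 1, so no step from compound 4 to compound 1, compound 2 or compound 3 can be read: the limit of < 100000 nM in this assay, at which 2 of the 4 values shown sit.

The compounds shown leave open whether any group other than pyrazin-2-yl and 1,3-thiazol-2-yl gives a readable number on that aromatic carbon.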